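This account rests on a few compounds, and the source may have more. Where it says the series, first, only, none or still open, it means among the compounds named here.

Measured compounds:
compound 1 `COc1cnc(-c2ccccn2)nc1N(C)C1CCCC1` — 180 nM
compound 2 `COc1cnc(-c2ccccn2)nc1N1CCCCCC1` — 690 nM

Both numbers come from a functional assay on RAW264.7 cells (Mus musculus), with a stated time of 3 days; a lower number here means a stronger inhibitor, a higher number a weaker inhibitor. Going by the values given here, compound 2 holds the highest of the two numbers; its nearest neighbour is compound 1, and the only measured step, a 3.8-fold higher number from compound 1 to compound 2 (0.58 log units; beyond the scatter), separates them. That step swaps one ring amine for another on the same aromatic carbon of the shared core.

Compound 3 `COc1cnc(-c2ccccn2)nc1C1CCCC1` is not yet measured. It differs from compound 2 in one place: cyclopentyl in place of azepan-1-yl on an aromatic carbon. Here the group entering carries no nitrogen at all, so the change is not a swap of one ring amine for another but the removal of the amine nitrogen together with a change of ring size. Among the compounds with values here, no measured step covers that; the step from compound 1 to compound 2 shows only what changing the ring amine does, and the two values of compound 1 and compound 2 give no handle on a carbon-linked ring. The estimate for compound 3 therefore rests on little: compound 3 is expected to stay near compound 2, with a 1.2-fold lower number from compound 2 to compound 3 (0.06 log units; within the scatter) expected to fall within the scatter, and a wide range around 600 nM from 150 nM to 2500 nM.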

Compound 3, half-maximal inhibitory concentration: 1800 nM
Estimate against measurement, compound 3: 3.0-fold (0.48 log units) below, and the stated range covers the measured number.
By their numbers in this assay, from the lowest: compound 1; then compound 2; then compound 3.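

In this assay, the position on the aromatic carbon next to the ring nitrogen, ortho to the methoxy group, proves sensitive to more than the choice of ring amine: both nitrogen-linked groups give lower numbers than the carbon-linked cyclopentyl of compound 3, which is the weakest of the three. The cleanest comparison keeps the cyclopentyl ring and removes the methylamino link, with a 10-fold higher number from compound 1 to compound 3 (1.00 log units; beyond the scatter), so the ring alone does not set the number at this position. Replacing the azepan-1-yl group changes ring size as well as removing the nitrogen, with a 2.6-fold higher number from compound 2 to compound 3 (0.42 log units; beyond the scatter), so that step cannot separate the two changes, and nothing on record gives a reason for either step.

Still open, on these data alone, is whether a small open-chain amine such as dimethylamino, or a ring amine with a further nitrogen such as piperazin-1-yl, would fall nearer compound 1 or compound 3. Also open, as far as these compounds go, is whether an oxygen link, as in cyclopentyloxy, would behave like the nitrogen link of compound 1 or the direct carbon link of compound 3.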